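Amino Replaces Aminomethyl on a Weak Topoisomerase Inhibitor Series

The source may hold more compounds than are shown below. What is called first, only, known or untested is meant among the compounds shown, and "the series" means these compounds.

Three compounds sharing a quinolone-type acid core were tested in an assay on isolated protein for inhibition of DNA topoisomerase 1 (Homo sapiens), with a stated time of 15 min; on this read-out higher numbers stand for weaker inhibition and lower numbers for stronger inhibition. Compound 3 `NC[C@@H]1CCN(c2cc3c(cc2F)c(=O)c(C(=O)O)cn3Cc2ccc(-c3ccccc3)cc2)C1` gives 15600 nM, and compound 1 `N[C@@H]1CCN(c2cc3c(cc2F)c(=O)c(C(=O)O)cn3Cc2ccc(-c3ccccc3)cc2)C1` gives 63600 nM. The change between them, (amino in place of aminomethyl on a saturated ring carbon), produces a 4.1-fold higher number from compound 3 to compound 1 (0.61 log units; beyond the scatter). Compound 2 `COc1c(N2CC[C@@H](CN)C2)c(F)cc2c(=O)c(C(=O)O)cn(Cc3ccc(-c4ccc(F)cc4)cc3)c12` gives 60900 nM; how its core differs from that of compound 3 is not broken down here. Compound 4 `COc1c(N2CC[C@@H](N)C2)c(F)cc2c(=O)c(C(=O)O)cn(Cc3ccc(-c4ccc(F)cc4)cc3)c12` is not yet measured. It differs from compound 2 by the same change, (amino in place of aminomethyl on a saturated ring carbon), at an identically described place. Because the earlier step of a 4.1-fold higher number from compound 3 to compound 1 (0.61 log units; beyond the scatter) weakened inhibition, a similar loss is expected here, so the step from compound 2 to compound 4 is estimated as a 3.3-fold higher number from compound 2 to compound 4 (0.52 log units; beyond the scatter). The value for compound 4 in this assay is therefore estimated at 200000 nM, likely between 70000 nM and 600000 nM, resting only on this single earlier step.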

Compound 4, half-maximal inhibitory concentration: 58600 nM
Compound 4: middle estimate off by 3.4-fold (0.53 log units), on the high side; measured number below the stated range.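

On the second core, putting amino in place of aminomethyl gives a 1.0-fold lower number from compound 2 to compound 4 (0.02 log units; within the scatter) in this assay. The same change therefore did not carry over with the same size from one core to the other: the same change on two cores in this assay, a 4.1-fold higher number (0.61 log units; beyond the scatter) from compound 3 to compound 1 and a 1.0-fold lower number (0.02 log units; within the scatter) from compound 2 to compound 4, 4.2-fold (0.63 log units) apart, beyond the scatter of two such steps. This shows that, in these two pairs, the earlier step cannot be relied on to predict the step on another core, but two pairs do not show which feature of the cores matters or how general this is.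

The compounds shown leave open how a longer chain, such as aminoethyl, would behave at this place on either core. They also leave open whether a hydroxyl group there would give steps that differ between the cores in the same way.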